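A few compounds are considered here, and "the series" means these few. Any claim that something is new, unique, unknown or untested is made for them only; others in the source may bear on it.

Compound 1 `OCc1cn(Cc2ccccc2)c2ccccc12` is the reference point of this small set. In a functional assay on T29Kt1 cells (Homo sapiens) for cytotoxicity, read by sulforhodamine B assay, with a stated time of 3 days (a lower number here means a stronger inhibitor, a higher number a weaker inhibitor), compound 1 gives 30 nM, the lowest number among the three compounds measured. Compound 2 `OCc1cn(Cc2ccccc2Cl)c2ccccc12` carries a chloro in place of hydrogen on an aromatic carbon, and in this assay compound 2 gives 2510 nM; this is an 84-fold higher number from compound 1 to compound 2 (1.92 log units; beyond the scatter). Compound 3 `OCc1cn(Cc2cccc(C(F)(F)F)c2)c2ccccc12` carries a trifluoromethyl in place of hydrogen on an aromatic carbon, and in this assay compound 3 gives 560 nM; this is a 19-fold higher number from compound 1 to compound 3 (1.27 log units; beyond the scatter). Both steps point the same way: adding a group to that aromatic ring weakened the compound.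

Compound 4 `COc1ccc(Cn2cc(CO)c3ccccc32)cc1` has not yet been measured. It differs from compound 1 by methoxy in place of hydrogen on an aromatic carbon. Neither the group nor its position on the ring matches the two measured steps exactly, so their sizes can only guide by analogy. Still, because both an 84-fold higher number from compound 1 to compound 2 (1.92 log units; beyond the scatter) and a 19-fold higher number from compound 1 to compound 3 (1.27 log units; beyond the scatter) were large losses, a weaker result than compound 1 is expected for compound 4 as well. The expected step is a 10-fold higher number from compound 1 to compound 4 (1.00 log units; beyond the scatter), and compound 4 is estimated at 300 nM, with a plausible range from 50 nM to 2000 nM.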

Compound 4, half-maximal inhibitory concentration: 63 nM
The estimate for compound 4 lay 4.8-fold (0.68 log units) above the measured number; low and high end bracket the measured number.
By their numbers in this assay, from the lowest: compound 1; then compound 4; then compound 3; then compound 2.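

In this assay, a group on this six-membered aromatic ring of carbon only need not cost much: methoxy, para to a large group, gives a 2.1-fold higher number from compound 1 to compound 4 (0.32 log units; beyond the scatter), a modest step, while the chloro change gave an 84-fold higher number from compound 1 to compound 2 (1.92 log units; beyond the scatter) and the trifluoromethyl change gave a 19-fold higher number from compound 1 to compound 3 (1.27 log units; beyond the scatter). The ring therefore accepts at least one added group with a far smaller loss, although compound 1, with only hydrogen on the ring, still has the lowest number of the four compounds. No evidence is available to explain why the methoxy step is the smallest.

The three groups stand at different places on the ring, so the effect of the group cannot be separated from the effect of its place. From the compounds shown here alone, how an amine, a carboxylic acid or a longer chain such as ethoxy would fare at the methoxy position also remains open.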